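Swapping an Ester for a Hydroxyethyl Group on the Phenyl Ring

This account rests on a few compounds, and the source may have more. Where it says the series, first, only, none or still open, it means among the compounds named here.

Of the compounds shown here, three built on a shared core have been measured in an assay for inhibition of 15-hydroxyprostaglandin dehydrogenase [NAD(+)] (Homo sapiens), read by fluorescence, with a stated time of 15 min, in the presence of a further agent that is not named here; on this read-out higher numbers stand for weaker inhibition and lower numbers for stronger inhibition. Compound 1 `CCC[S+]([O-])c1sc2nc(-c3cccs3)cc(-c3ccccc3)c2c1N` gives 2.1 nM. Compound 2 `CCCC[S+]([O-])c1sc2nc(-c3nccs3)cc(-c3ccc(C(=O)OC)cc3)c2c1N` gives 15.1 nM, the higher of the two numbers; compound 1 sits below it, beyond the scatter. Compound 3 `Nc1c(C(=O)O)sc2nc(-c3cccs3)cc(-c3ccccc3)c12` reaches only a limit in this assay, > 7500 nM, as noted in the limit of > 7500 nM in this assay, at which 1 of the 3 values shown sits. Among the compounds with values here, the single measured step, an at least 3500-fold higher number from compound 1 to compound 3 (3.55 log units; beyond the scatter), concerns the group on the core and not the phenyl ring.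

Compound 4 `CCCC[S+]([O-])c1sc2nc(-c3nccs3)cc(-c3ccc(CCO)cc3)c2c1N` is compound 2 with 2-hydroxyethyl in place of methoxycarbonyl on an aromatic carbon. Within the data shown here, no measured step touches that ring, so the only guide is compound 2 itself in this assay. The change is expected to stay within the scatter, giving a 1.0-fold lower number from compound 2 to compound 4 (0.00 log units; within the scatter) for compound 4. Compound 4 is therefore estimated at 15 nM in this assay, with a range from 5 nM to 50 nM.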

Compound 4, half-maximal inhibitory concentration: 2.9 nM
Compound 4: middle estimate off by 5.2-fold (0.71 log units), on the high side, and the stated range ends above it.
By their numbers in this assay, from the lowest: compounds 1 and 4 (each within the scatter of the next); then compound 2. At a limit, above all of these: compound 3.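

Within the data shown here, the group on the phenyl ring, which no earlier step had touched, proves to matter in this assay: 2-hydroxyethyl in place of methoxycarbonyl gives a 5.2-fold lower number from compound 2 to compound 4 (0.72 log units; beyond the scatter). This position is therefore not silent on this read-out, and the change runs toward stronger inhibition with the group that carries a hydrogen-bond donor and lacks the double bond outside aromatic rings, although a single pair cannot separate these counted differences. Nothing measured here bears on the cause of this step.

From the compounds shown here alone, it remains open whether a carboxylic acid, an amine or a longer chain ending in a hydroxyl at the same place would follow the same direction. Going by these compounds, it is also open whether the step would hold with the other groups of compound 1 on the shared core.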